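Swapping Isobutyl for 3,3-Dimethyloxiran-2-yl in Compound 2

A few compounds are considered here, and "the series" means these few. Any claim that something is new, unique, unknown or untested is made for them only; others in the source may bear on it.

In a functional assay on A549 cells (Homo sapiens) for inhibition, read by sulforhodamine B assay, with a stated time of 48 h, tested at 50 uM (a lower number here means less inhibition of growth, a higher number more inhibition of growth at the concentration tested), compound 1 `CCCOc1ccc([C@@H]2CC(=O)c3cc(CC=C(C)C)c(OC)cc3O2)cc1` gives 43%, while compound 2 `COc1cc2c(cc1CCC(C)C)C(=O)C[C@@H](c1ccc(O)cc1)O2` gives 75%. Compound 2 therefore holds the higher of the two numbers, and the gap between them lies beyond the usual scatter. Compound 3 `COc1cc2c(cc1CC1OC1(C)C)C(=O)C[C@@H](c1ccc(O)cc1)O2` carries 3,3-dimethyloxiran-2-yl in place of isobutyl on a saturated chain carbon bound to an aromatic carbon. Within the data shown here, no measured pair differs in one place only, so the data offer no direct guide to this change. A modest fall in this assay is expected, starting from compound 2 at 75%, with compound 1 at 43% as the only lower reference. The estimated change is a number 12 percentage points lower from compound 2 to compound 3 (beyond the scatter). For compound 3, the expected value is 63%, within an estimated range of 40% to 85%.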

Compound 3, percent growth inhibition at one concentration: 79%
Estimate against measurement, compound 3: 16 percentage points below, and the stated range covers the measured number.
By their numbers in this assay, from the lowest: compound 1; then compounds 2 and 3 (each within the scatter of the next).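

In this assay, among these compounds, the exchange of isobutyl for 3,3-dimethyloxiran-2-yl on a saturated chain carbon bound to an aromatic carbon comes out as a number 4 percentage points higher from compound 2 to compound 3 (within the scatter), the first comparison here that differs in one place only. At this position, then, a three-membered ring carrying an oxygen and a hydrogen-bond acceptor took the place of an open, acceptor-free group with no change beyond the scatter. Nothing available explains this outcome.

The compounds shown leave open whether an amine, a carboxylic acid or a longer chain at the same place would also leave the number within the scatter. They also leave open whether compound 2 and compound 3 would stay this close at other concentrations, since the read-out comes from one concentration alone.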